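The source may report more compounds than this note shows. Statements on the series, on what has been measured and on what is new or still open speak of the compounds shown alone.

Measured compounds in this series:

compound 1, `O=c1ccc(-c2ccccc2)nn1CCCCNC(=S)Nc1ccc(Cl)cc1`: > 100 mg/kg
compound 2, `C/N=C(/NC#N)NCCCCCn1nc(-c2ccccc2)c(C)cc1=O`: > 100 mg/kg
compound 3, `CC/N=C(/NC#N)NCCCCCCn1nc(-c2ccccc2)ccc1=O`: > 100 mg/kg

In a functional assay on the whole organism (stomach) with Rattus norvegicus as the target (a higher number here means that more compound is needed for the effect, a lower number that less compound is needed), compound 1 gives > 100 mg/kg, which is a limit of the assay and not a number. Compound 2 gives > 100 mg/kg, again a limit. Compound 3 gives > 100 mg/kg, likewise a limit. The three values thus coincide at the limit of > 100 mg/kg in this assay, at which 3 of the 3 values shown sit, and compound 1 cannot be placed relative to compound 2 or compound 3; the numbers show only that none of the three reached a half-maximal effect within the dosed range.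

Compound 4, `O=c1ccc(-c2ccccc2)nn1CCCCNC(=S)Nc1ccccc1`, is not yet measured in this assay. It differs from compound 1 by hydrogen in place of chloro on an aromatic carbon. Going by the values given here, no step between measured compounds exists, so no size for such a change can be read from the data. The expected step is a step that the limit leaves unreadable from compound 1 to compound 4, none beyond the scatter in either direction. Among the compounds with values here, compound 4 is expected most likely to return only a limit as well, because the limit of > 100 mg/kg in this assay, at which 3 of the 3 values shown sit, covers every value measured so far. Should a number result, compound 4 is estimated at 150 mg/kg, with a range from 60 mg/kg to 400 mg/kg.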

Compound 4, dose for half-maximal effect: > 100 mg/kg
Compound 4 was reported as a limit; the forecaster's own chance of this, stated with the estimate: 80%; the middle value does not contradict the limit.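

In this assay compound 4 gives > 100 mg/kg, which is a limit of the assay and not a number. Compound 1 also stands at a limit, so no step can be read for the change from 4-chlorophenyl to phenyl between compound 1 and compound 4: the limit of > 100 mg/kg in this assay, at which 4 of the 4 values shown sit.

The compounds shown leave open what dose, if any, gives a half-maximal effect in this series.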